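The compounds below may be only part of what the source reports. "The series", "measured", "known", "first", "only" and "open" are said of these compounds alone.

Two measured compounds bear on this step. Compound 1 `CC(=O)N(C)C(C)C#CCn1cncc1C` gives 1.1 mg/kg in a functional assay on the whole organism for antagonist activity, with Mus musculus as the target; a higher number here means that more compound is needed for the effect, a lower number that less compound is needed. Compound 2 `COC(=O)N(C)C(C)C#CCn1ccnc1` returns only a limit of the assay, > 100 mg/kg, and no number is known for it. Its standing in this assay is therefore (the limit of > 100 mg/kg in this assay, at which 1 of the 2 values shown sits).

Compound 3 `COC(=O)N(C)C(C)C#CCn1cncc1C` is compound 2 with methyl in place of hydrogen on an aromatic carbon of the five-membered aromatic ring with 2 nitrogen, next to the ring nitrogen and next to the ring atom that bears a large group: methyl in place of hydrogen on an aromatic carbon.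

Among the compounds with values here, no measured pair isolates this change, so the expectation rests on indirect ground. The same ring methyl is present in compound 1, at 1.1 mg/kg, though compound 1 is not otherwise identical to compound 3. The expected change an at least 10-fold lower number from compound 2 to compound 3 (1.00 log units; beyond the scatter) is large and lies beyond the scatter, toward less compound needed. On these data alone, its true size remains open, and compound 3 could also return only a limit. For compound 3 the estimated dose is 10 mg/kg, with an expected range of 2 mg/kg to 60 mg/kg.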

Compound 3, dose for half-maximal effect: 3.7 mg/kg
Compound 3: the middle estimate sits 2.7-fold (0.43 log units) above what was measured; low and high end bracket the measured number.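

Within the data shown here, the single change of methyl in place of hydrogen on an aromatic carbon, next to the ring nitrogen and next to the ring atom that bears a large group, now has a measured pair in this assay, which gives an at least 27-fold lower number from compound 2 to compound 3 (1.43 log units; beyond the scatter) for this position. Compound 2 holds only a limit of the assay, so the step has a floor on its size and no exact size: the limit of > 100 mg/kg in this assay, at which 1 of the 3 values shown sits. With the ring methyl present in both compounds, methoxy in place of methyl on a carbonyl carbon gives a 3.4-fold higher number from compound 1 to compound 3 (0.53 log units; beyond the scatter) and is a smaller step than the one at the ring carbon.

On these data alone, whether ethyl, chlorine or trifluoromethyl on this ring carbon would read like methyl stays open, as does the size of the effect of methyl itself with methyl on the carbonyl carbon. Also open, as far as these compounds go, is how a longer chain on the carbonyl carbon, such as ethoxy in place of methoxy, would read with the ring methyl in place.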